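Hydroxymethyl replacing the sulfur group at the assay limit

A few compounds are considered here, and "the series" means these few. Any claim that something is new, unique, unknown or untested is made for them only; others in the source may bear on it.

In a functional assay on HeLa cells (Homo sapiens) for cytotoxicity, read by neutral red uptake, with a stated time of 3 days (on this read-out lower numbers stand for stronger inhibition and higher numbers for weaker inhibition), compound 3 (`C[S+]([O-])c1c(F)c(N)c2c(=O)cc(-c3ccc(N)c(F)c3)oc2c1F`) gives > 100000 nM as a limit and not a number. Compound 1 (`Nc1ccc(-c2cc(=O)c3c(N)c(F)cc(F)c3o2)cc1F`) gives > 100000 nM as a limit too. Compound 2 (`Nc1ccc(-c2cc(=O)c3c(N)c(F)c(Br)c(F)c3o2)cc1F`) gives > 100000 nM as a limit as well. Among the compounds with values here, compound 3 therefore has no readable rank, and the series so far stands at the limit of > 100000 nM in this assay, at which 3 of the 3 values shown sit, without any compound placed ahead of another.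

Compound 4 (`Nc1ccc(-c2cc(=O)c3c(N)c(F)c(CO)c(F)c3o2)cc1F`) carries the change a group of 2 heavy atoms (1 carbon, 1 oxygen; no ring) in place of a group of 3 heavy atoms (1 carbon, 1 oxygen, 1 sulfur; no ring), on an aromatic carbon on an aromatic carbon ortho to two fluoro groups, where hydroxymethyl enters.

Within the data shown here, three measured steps concern this same carbon: a step that the two limits leave unreadable from compound 1 to compound 2 for bromo in place of hydrogen, a step that the two limits leave unreadable from compound 1 to compound 3 for the leaving group in place of hydrogen, and a step that the two limits leave unreadable from compound 2 to compound 3 for that group in place of bromine. None of them has a readable size, so there is no measured size to carry over. Hydrogen, bromo and the leaving group all end at the same limit, and none of the three compounds goes against this. Among the measured compounds shown here, no step of readable size and no direction is therefore expected in this assay for hydroxymethyl. The expected step is a number no higher from compound 3 to compound 4 (the limit leaves the size open) as an estimate. The estimate for compound 4 is 100000 nM and the expected range runs from 30000 nM to 300000 nM on this read-out, most likely reported again as a limit.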

Compound 4, half-maximal inhibitory concentration: 24000 nM
For compound 4 the middle estimate is 4.2-fold (0.62 log units) above the measured one; the whole stated range lies above it.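

At the aromatic carbon ortho to two fluoro groups, this assay now separates one compound from the others: hydroxymethyl in place of hydrogen gives an at least 4.1-fold lower number from compound 1 to compound 4 (0.61 log units; beyond the scatter), in place of bromo it gives an at least 4.1-fold lower number from compound 2 to compound 4 (0.61 log units; beyond the scatter), and in place of the sulfur group it gives an at least 4.1-fold lower number from compound 3 to compound 4 (0.61 log units; beyond the scatter). These three steps are bounds and not sizes, since each starts from a limit, and the steps among compound 1, compound 2 and compound 3 cannot be read at all. This carbon is therefore a place where a change can bring a measurable number on this read-out, and compound 4 is the only compound shown that has one, while the rest of the series stays at the limit: the limit of > 100000 nM in this assay, at which 3 of the 4 values shown sit.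

Going by these compounds, since the true values of compound 1, compound 2 and compound 3 lie beyond the limit, the full size of the hydroxymethyl step remains open. Also open, on these data alone, is whether the hydroxyl matters or any small carbon group would serve, which methyl, methoxy, aminomethyl, a carboxylic acid or a longer chain such as 2-hydroxyethyl at this carbon could settle.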